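The compounds below may be only part of what the source reports. "The series", "measured", "known", "first", "only" and "open" are said of these compounds alone.

Series notes. Compound 1 `Fc1ccc(C2CC(c3ccccc3)=NN2c2ccc(-c3ccccc3)nn2)cc1` and compound 2 `FC(F)(F)c1ccc(C2CC(c3ccccc3)=NN2c2ccc(-c3ccccc3)nn2)cc1` share one core; compound 3 `Fc1ccc(C2CC(c3ccc(Cl)cc3)=NN2c2ccc(-c3ccccc3)nn2)cc1` and compound 4 `FC(F)(F)c1ccc(C2CC(c3ccc(Cl)cc3)=NN2c2ccc(-c3ccccc3)nn2)cc1` share another, and the two cores differ by chloro in place of hydrogen on an aromatic carbon. In a functional assay on MCF7 cells (Homo sapiens) for antiproliferative activity, read by MTT assay, with a stated time of 24 h (a higher number here means a weaker inhibitor, a lower number a stronger inhibitor), compound 1 gives 100000 nM, compound 2 gives 100000 nM and compound 3 gives 3750 nM. The step of a 27-fold lower number from compound 1 to compound 3 (1.43 log units; beyond the scatter) is the only one here that moves beyond the scatter. The change trifluoromethyl in place of fluoro on an aromatic carbon gave no change at the digits printed from compound 1 to compound 2 (within the scatter). The same change, (trifluoromethyl in place of fluoro on an aromatic carbon), is now made on the core of compound 3, at a place described in the same words. The step from compound 3 to compound 4 in this assay is expected to be a 1.2-fold higher number from compound 3 to compound 4 (0.08 log units; within the scatter), resting on the earlier pair, since only compound 1 and compound 2 show this change. Compound 4 is estimated at 4500 nM, expected within 1500 nM to 20000 nM.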

Compound 4, half-maximal inhibitory concentration: 1670 nM
Estimate against measurement, compound 4: 2.7-fold (0.43 log units) above; low and high end bracket the measured number.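

In this assay, trifluoromethyl in place of fluoro gives a 2.2-fold lower number from compound 3 to compound 4 (0.35 log units; beyond the scatter), and this step agrees with the one on the other core: the same change on two cores in this assay, no change at the digits printed (within the scatter) from compound 1 to compound 2 and a 2.2-fold lower number (0.35 log units; beyond the scatter) from compound 3 to compound 4, 2.2-fold (0.35 log units) apart, within the scatter of two such steps. Chloro in place of hydrogen gives a 60-fold lower number from compound 2 to compound 4 (1.78 log units; beyond the scatter), and it too agrees with its earlier counterpart: the same change on two cores in this assay, a 27-fold lower number (1.43 log units; beyond the scatter) from compound 1 to compound 3 and a 60-fold lower number (1.78 log units; beyond the scatter) from compound 2 to compound 4, 2.2-fold (0.35 log units) apart, within the scatter of two such steps. Going by these compounds alone, each change is seen on only two cores, so the agreement holds for compounds 1 to 4 and does not show that either change would carry to a further core or to another assay.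

As far as these compounds go, how an amine or a carboxylic acid would behave in place of fluoro on that aromatic carbon remains open. So does whether a methoxy group could stand in for the chloro.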